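This account rests on a few compounds, and the source may have more. Where it says the series, first, only, none or still open, it means among the compounds named here.

Working notes on the series, all read in a functional assay on A-375 cells (Homo sapiens) for antiproliferative activity, read by MTT assay, with a stated time of 24 h; a lower number here means a stronger inhibitor, a higher number a weaker inhibitor. Of the compounds shown here, two have numbers so far: compound 1 `Cc1c(C(=O)Nc2c(F)cc(-c3cccc(F)c3)cc2F)nc2ccc(OC(F)(F)F)cc2c1O` gives 38300 nM, and compound 2 `COc1ccc2nc(C(=O)Nc3ccc(-c4ccccc4)cc3)c(C)c(O)c2c1` gives 50600 nM. These two values lie within the scatter of each other, so compound 2 stands level with compound 1, and no order can be drawn between them.

Among the compounds with values here, the next entry is compound 3 `Cc1c(C(=O)Nc2ccc(-c3ccccc3)cc2)nc2ccccc2c1O`, which has no measurement yet. Relative to compound 2, the change is hydrogen in place of methoxy on an aromatic carbon. Within the data shown here, no measured pair isolates this change, so the data give no direct precedent for its size or direction. Among the measured compounds shown here, the only guide is the narrow spread of the two numbers in hand, with compound 1 at 38300 nM and compound 2 at 50600 nM. The expectation in this assay is therefore no shift beyond the scatter and no firm direction. The estimated step of a 1.1-fold lower number from compound 2 to compound 3 (0.05 log units; within the scatter) is expected to stay within that scatter. For compound 3 the expected value is 45000 nM, with an estimated range of 20000 nM to 100000 nM.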

Compound 3, half-maximal inhibitory concentration: 75500 nM
The estimate for compound 3 lay 1.7-fold (0.22 log units) below the measured number, within the range that was stated.
By their numbers in this assay, from the lowest: compounds 1, 2 and 3 (each within the scatter of the next).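

Within the data shown here, compound 2 and compound 3 form the first pair that differs in one place, and in this assay hydrogen in place of methoxy on an aromatic carbon amounts to a 1.5-fold higher number from compound 2 to compound 3 (0.17 log units; within the scatter) and so stays within the scatter. At this carbon of the six-membered aromatic ring, meta to a fused ring and para to a fused ring, the loss of the methoxy group and its 2 heavy atoms therefore gives no shift that this assay can separate from repeat variation, and this single pair sets no direction for the position. Nothing in hand accounts for the size of this step or links it to any property of the methoxy group.

Still open, as far as these compounds go, is whether any other group at this carbon, such as an amine, a carboxylic acid or a longer alkoxy chain, would move the number beyond the scatter. Compound 1 carries trifluoromethoxy on the core but also differs elsewhere, so the effect of that group cannot be read from the compounds shown.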